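Swapping a Sulfonamide Hydrogen for a Dimethylpyrimidine Ring

The compounds below may be only part of what the source reports. "The series", "measured", "known", "first", "only" and "open" are said of these compounds alone.

Of the compounds shown here, three sharing a chloro-coumarin imine core have been tested in a functional assay on B16-F10 cells (Mus musculus) for cytotoxicity, read by CCK-8 assay, with a stated time of 48 h; a higher number here means a weaker inhibitor, a lower number a stronger inhibitor. Compound 1 `N=C(N)NS(=O)(=O)c1ccc(/N=C/c2c(Cl)c3ccccc3oc2=O)cc1` gives 180 nM, and compound 2 `Cc1cc(NS(=O)(=O)c2ccc(/N=C/c3c(Cl)c4ccccc4oc3=O)cc2)no1` gives 270 nM. Compound 3 `CC(C)(C)c1cc(C(C)(C)C)c2oc(=O)c(/C=N/c3ccc(S(N)(=O)=O)cc3)c(Cl)c2c1`, whose core carries two tert-butyl groups and whose sulfonamide nitrogen is unsubstituted, gives 240 nM; its number sits between those of the other two, nearest to compound 2 and furthest from compound 1, with both gaps inside the scatter.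

Compound 4 `Cc1cc(C)nc(NS(=O)(=O)c2ccc(/N=C/c3c(Cl)c4cc(C(C)(C)C)cc(C(C)(C)C)c4oc3=O)cc2)n1` is not yet measured. It differs from compound 3 in one place: 4,6-dimethylpyrimidin-2-yl in place of hydrogen on a sulfonamide nitrogen. For the measured compounds named here, the only measured step at that same position is a 1.5-fold higher number from compound 1 to compound 2 (0.18 log units; within the scatter), which swapped one nitrogen-bearing substituent for another and left the number essentially unchanged. Going by the values given here, no measured pair shows what happens when a bare sulfonamide hydrogen is replaced by a ring, and the two tert-butyl groups of compound 3 make the comparison with compounds 1 and 2 indirect.

Given how little the sulfonamide substituent moved the number in a 1.5-fold higher number from compound 1 to compound 2 (0.18 log units; within the scatter), compound 4 is expected to stay close to compound 3, with no change at the digits printed from compound 3 to compound 4 (within the scatter) being the estimated step. The estimated value for compound 4 in this assay is 240 nM, within a range of 100 nM to 550 nM.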

Compound 4, half-maximal inhibitory concentration: 220 nM
Compound 4: the middle estimate sits 1.1-fold (0.04 log units) above what was measured; low and high end bracket the measured number.
By their numbers in this assay, from the lowest: compounds 1, 4, 3 and 2 (each within the scatter of the next).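

In this assay, for the compounds shown here, 4,6-dimethylpyrimidin-2-yl in place of hydrogen on a sulfonamide nitrogen gives a 1.1-fold lower number from compound 3 to compound 4 (0.04 log units; within the scatter) and so supplies what the earlier compounds lacked: a direct pair with a bare hydrogen on one side. The earlier step, a 1.5-fold higher number from compound 1 to compound 2 (0.18 log units; within the scatter), only exchanged one substituent on that nitrogen for another, whereas here 4,6-dimethylpyrimidin-2-yl, with one six-membered aromatic ring, enters where no heavy atom stood, and the two numbers still cannot be told apart. On the core carrying two tert-butyl groups, this position therefore accepts this ring without a change beyond the scatter, though no measurement here offers an explanation.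

The compounds shown leave open whether the same holds on the core without the tert-butyl groups, since the dimethylpyrimidine ring appears only on the core of compound 3. They also leave open whether a very different group on the sulfonamide nitrogen, such as a carboxylic acid on a longer chain or a simple primary amine, would keep the number within the scatter or move it beyond.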